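The source may hold more compounds than are shown below. What is called first, only, known or untested is meant among the compounds shown, and "the series" means these compounds.

In a physicochemical assay for solubility, read by HPLC, in phosphate buffer, measured as kinetic solubility, at pH 7.4 (a lower number here means a less soluble compound, a higher number a more soluble compound), compound 1 `CCOC(=O)c1cc(-c2ccc(F)cc2)n(-c2ccc(S(N)(=O)=O)cc2)c1` gives 36400 nM, compound 2 `CCC(=O)c1cc(-c2ccc(S(N)(=O)=O)cc2)n(-c2ccc(Cl)cc2)n1` gives 41900 nM and compound 3 `CCOC(=O)c1cc(-c2ccc(Cl)cc2)n(-c2ccc(S(N)(=O)=O)cc2)n1` gives 53300 nM. Compound 2 therefore stands level with the other two, and its gaps to both lie within the usual scatter of repeated measurements. Compound 4 `NS(=O)(=O)c1ccc(-c2cc(C(=O)C3CC3)nn2-c2ccc(Cl)cc2)cc1` is compound 2 with a single change: cyclopropyl in place of ethyl on a carbonyl carbon. Among the measured compounds shown here, no measured pair isolates this change, or any other single change, so the data give no direct guide. In this assay, no step beyond the scatter is expected. The estimated step, a 1.2-fold lower number from compound 2 to compound 4 (0.08 log units; within the scatter), stays within that scatter. For compound 4, the estimated value is 35000 nM, with an expected range from 15000 nM to 70000 nM.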

Compound 4, solubility: 25600 nM
The estimate for compound 4 lay 1.4-fold (0.14 log units) above the measured number; the range from low to high includes it.
By their numbers in this assay, from the lowest: compounds 4, 1, 2 and 3 (each within the scatter of the next, the first and the last beyond it).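

In this assay, among the compounds shown here, cyclopropyl in place of ethyl on a carbonyl carbon gives a 1.6-fold lower number from compound 2 to compound 4 (0.21 log units; within the scatter) and so provides the first reading of a single change in this set. At this position, then, this one swap of ethyl for a three-membered carbon ring leaves the number within the scatter. No supporting measurement bears on this result.

As far as these compounds go, whether a longer chain or an amine on that carbonyl carbon would give a step beyond the scatter remains open. So does whether the same change would behave alike on the core of compound 1.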